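The compounds below may be only part of what the source reports. "The series", "measured", "known", "first", "only" and "open" are said of these compounds alone.

In a physicochemical assay for solubility, measured as kinetic solubility, at pH 2 (on this read-out higher numbers stand for higher solubility and lower numbers for lower solubility), compound 3 `CC(C)C(Cc1nnn[nH]1)c1ccc(-c2ccc3cccc(F)c3c2)[nH]c1=O` gives 28000 nM, the second highest of the three numbers shown; its nearest neighbour is compound 1 `CC(C)C(Nc1nccs1)c1ccc(-c2ccc3cccc(F)c3c2)[nH]c1=O`, which gives 32900 nM, and its furthest is compound 2 `CC(C)C(/C=C1\CCNC1=O)c1ccc(-c2ccc3cccc(F)c3c2)[nH]c1=O`, which gives 23600 nM. Compound 4 `CC(C)C(CC(N)=O)c1ccc(-c2ccc3cccc(F)c3c2)[nH]c1=O` differs from compound 3 by carbamoyl in place of 1H-tetrazol-5-yl on a saturated chain carbon, two bonds along the chain from an aromatic carbon. The steps measured so far all exchange the group at this same place: a 1.2-fold lower number from compound 1 to compound 3 (0.07 log units; within the scatter) and a 1.2-fold higher number from compound 2 to compound 3 (0.07 log units; within the scatter), both within the scatter, as is a 1.4-fold lower number from compound 1 to compound 2 (0.14 log units; within the scatter). Three groups of quite different kind at this position have thus left this assay without a step beyond the scatter, so compound 4 is expected to show no change at the digits printed from compound 3 to compound 4 (within the scatter), nothing beyond the scatter. Compound 4 is therefore estimated at 28000 nM, with a range from 14000 nM to 56000 nM.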

Compound 4, solubility: 3120 nM
Estimate against measurement, compound 4: 9.0-fold (0.95 log units) above, and the stated range ends above it.
By their numbers in this assay, from the lowest: compound 4; then compounds 2, 3 and 1 (each within the scatter of the next).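

In this assay, for the compounds shown here, this position is not indifferent to every group: carbamoyl in place of 1H-tetrazol-5-yl gives a 9.0-fold lower number from compound 3 to compound 4 (0.95 log units; beyond the scatter) and so, unlike the earlier steps, passes beyond the scatter. The other two steps run the same way, with a 7.6-fold lower number from compound 2 to compound 4 (0.88 log units; beyond the scatter) and an 11-fold lower number from compound 1 to compound 4 (1.02 log units; beyond the scatter) set beside it, so compound 4 stands apart from compounds 1, 2 and 3, which lie within the scatter of one another. Nothing measured here gives a reason for this separation.

The compounds shown leave open whether the drop belongs to carbamoyl alone or also extends to other small open-chain groups. A carboxylic acid, an amine or a longer chain ending in carbamoyl at this place would help to decide that.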